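A few compounds are considered here, and "the series" means these few. Any claim that something is new, unique, unknown or untested is made for them only; others in the source may bear on it.

Of the compounds shown here, three built on closely related scaffolds have been tested in a functional assay on cells (Cancer cell lines, Homo sapiens) for cytotoxicity, read by sulforhodamine B assay, with a stated time of 48 h; on this read-out lower numbers stand for stronger inhibition of growth and higher numbers for weaker inhibition of growth. Compound 1 `COc1ccc(C2=NN(C3=NC(=O)/C(=C4\C(=O)Nc5ccc(Br)cc54)S3)C(c3ccc(Cl)cc3)C2)cc1` gives 130 nM in this assay. Compound 2 `COc1ccc(C2=NN(C3=NC(=O)/C(=C4\C(=O)Nc5ccc(Cl)cc54)S3)C(c3ccc(Cl)cc3)C2)cc1` differs from it by chloro in place of bromo on an aromatic carbon and gives 210 nM in this assay, a shift of a 1.6-fold higher number from compound 1 to compound 2 (0.21 log units; within the scatter). Compound 3 `CN(C)c1ccc(C2CC(c3ccccc3)=NN2C2=NC(=O)/C(=C3\C(=O)Nc4ccc(Br)cc43)S2)cc1` carries a different core from compound 1; how the two cores differ is not broken down here. In this assay, among the compounds with values here, compound 3 gives 200 nM, a number that sits close to the one for compound 2.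

Compound 4 `CN(C)c1ccc(C2CC(c3ccccc3)=NN2C2=NC(=O)/C(=C3\C(=O)Nc4ccc(Cl)cc43)S2)cc1` has not yet been measured. It differs from compound 3 by chloro in place of bromo on an aromatic carbon, and this is the same change that turns compound 1 into compound 2, since the place is described in identical words for both pairs. That change has been seen once so far and moved the number only a little. The expected step is a 1.4-fold higher number from compound 3 to compound 4 (0.15 log units; within the scatter) because a 1.6-fold higher number from compound 1 to compound 2 (0.21 log units; within the scatter) came from the very same change. Compound 4 is therefore estimated at 280 nM in this assay, with a likely range from 140 nM to 560 nM.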

Compound 4, concentration for 50% growth inhibition: 190 nM
Beside the measured number, compound 4's estimate is 1.5-fold (0.17 log units) above it, within the range that was stated.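

In this assay, chloro in place of bromo on the aromatic carbon gives a 1.1-fold lower number from compound 3 to compound 4 (0.02 log units; within the scatter), so on this second core the step again stays within the usual spread of repeated measurements. Set side by side, the two steps do not differ by more than that spread allows: the same change on two cores in this assay, a 1.6-fold higher number (0.21 log units; within the scatter) from compound 1 to compound 2 and a 1.1-fold lower number (0.02 log units; within the scatter) from compound 3 to compound 4, 1.7-fold (0.23 log units) apart, within the scatter of two such steps This shows that, for these two cores, the swap carries over without any detectable dependence on the core, and that either halogen serves about equally well here; it does not show that the same would hold on other cores, since only two pairs are available and neither step is large enough to reveal a real effect of the change.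

The compounds shown carry only bromo or chloro at this place, so it remains open whether a larger change, such as a methoxy group, an amine or a carboxylic acid on the same carbon, would move the number clearly. From the compounds shown here alone, it also remains open whether such a change would then carry over from one core to the other as closely as this swap does.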